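Trifluoromethyl on the aryl ring of dienone cytotoxins

A few compounds are considered here, and "the series" means these few. Any claim that something is new, unique, unknown or untested is made for them only; others in the source may bear on it.

Measured so far in a functional assay on PC-3 cells (Homo sapiens) for cytotoxicity, read by MTT assay, with a stated time of 72 h; on this read-out higher numbers stand for weaker inhibition and lower numbers for stronger inhibition:
compound 1 `CC1=C(/C=C/C(=O)/C=C/c2cccc(C(F)(F)F)c2)C(C)(C)CCC1` gives 7700 nM
compound 2 `CC1=C(/C=C/C(=O)/C=C/c2cc(C(F)(F)F)cc(C(F)(F)F)c2)C(C)(C)CCC1` gives 7200 nM
compound 3 `CC1=C(/C=C/C(=O)/C=C/c2ccccc2F)C(C)(C)CCC1O` gives 10400 nM

The three numbers lie close together. From compound 1 to compound 2 the change is trifluoromethyl in place of hydrogen on an aromatic carbon and the step was a 1.1-fold lower number from compound 1 to compound 2 (0.03 log units; within the scatter). Compound 3 stands apart from compound 1 by more than one feature, and the difference between the two cores is not broken down here; its value and that of compound 1 lie within the scatter of each other.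

Compound 4 `CC1=C(/C=C/C(=O)/C=C/c2cc(C(F)(F)F)ccc2F)C(C)(C)CCC1O` is not yet measured. It arises from compound 3 by trifluoromethyl in place of hydrogen on an aromatic carbon. This is the same kind of change as that from compound 1 to compound 2, though the surroundings differ: in compound 4 the new group is para to a fluoro group, whereas in compound 2 it is meta to a trifluoromethyl group. Because the earlier step was a 1.1-fold lower number from compound 1 to compound 2 (0.03 log units; within the scatter), the step from compound 3 to compound 4 in this assay is expected to be a 1.1-fold lower number from compound 3 to compound 4 (0.04 log units; within the scatter). Compound 4 is estimated at 9500 nM, between 4000 nM and 22000 nM.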

Compound 4, half-maximal inhibitory concentration: 3600 nM
Compound 4: middle estimate off by 2.6-fold (0.42 log units), on the high side; measured number outside the range, below it.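

On the core of compound 3, trifluoromethyl in place of hydrogen on an aromatic carbon gave a 2.9-fold lower number from compound 3 to compound 4 (0.46 log units; beyond the scatter) in this assay, a modest step beyond the scatter. The size of this change therefore did not carry over unchanged between the two cores: the same change on two cores in this assay, a 1.1-fold lower number (0.03 log units; within the scatter) from compound 1 to compound 2 and a 2.9-fold lower number (0.46 log units; beyond the scatter) from compound 3 to compound 4, 2.7-fold (0.43 log units) apart, beyond the scatter of two such steps. This does not show what sets the two steps apart, since the pairs differ both in the core and in what else the aromatic ring carries, with the new group para to a fluoro group in compound 4, and two steps in a single assay cannot separate these features or establish a rule for the series.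

The compounds shown leave open whether the step on the core of compound 3 would persist without that fluoro group. They also leave open whether a nitrile or a chlorine atom in the same place would give a step of similar size.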